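Swapping methyl for sulfamoyl on compound 2

A few compounds are considered here, and "the series" means these few. Any claim that something is new, unique, unknown or untested is made for them only; others in the source may bear on it.

In an ADME assay on MT4 cells (Homo sapiens) for cytotoxicity (a higher number here means that more compound is tolerated, a lower number that less compound is tolerated), compound 1 `Cc1cc(C)cc(Cn2c(SCC(=O)Nc3ccccc3[N+](=O)[O-])nc3ccccc32)c1` gives 194000 nM, compound 2 `Cc1cc(C)cc(Cn2c(SCC(=O)Nc3ccc(C)cc3Cl)nc3ccccc32)c1` gives 49200 nM and compound 3 `Cc1cc(C)cc(S(=O)(=O)n2c(SCC(=O)Nc3ccc(C)cc3Cl)nc3ccccc32)c1` gives 5400 nM, so compound 2 is second highest of the three. Compound 4 `Cc1cc(C)cc(Cn2c(SCC(=O)Nc3ccc(S(N)(=O)=O)cc3Cl)nc3ccccc32)c1` differs from compound 2 in one group: sulfamoyl in place of methyl on an aromatic carbon. The step of a 9.1-fold lower number from compound 2 to compound 3 (0.96 log units; beyond the scatter) changed the group on an aromatic nitrogen, so it offers little guidance here. The step of a 3.9-fold lower number from compound 1 to compound 2 (0.60 log units; beyond the scatter) changed the group on the amide-type nitrogen, where the new swap also falls, and brought the methyl in. Losing that methyl may reverse part of this drop, but no measured compound carries sulfamoyl. The expected change is modest, a 1.8-fold higher number from compound 2 to compound 4 (0.26 log units; within the scatter). For compound 4 the estimated value is 90000 nM, within an expected range of 30000 nM to 250000 nM.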

Compound 4, half-maximal cytotoxic concentration: 111000 nM
Compound 4: middle estimate off by 1.2-fold (0.09 log units), on the low side, and the stated range covers the measured number.
By their numbers in this assay, from the lowest: compound 3; then compound 2; then compounds 4 and 1 (each within the scatter of the next).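

In this assay sulfamoyl in place of methyl gives a 2.3-fold higher number from compound 2 to compound 4 (0.35 log units; beyond the scatter) and so shows that this position, para to a large group, takes the larger group without a drop in the number. Putting 2-chloro-4-sulfamoylphenyl in place of 2-nitrophenyl gives a 1.7-fold lower number from compound 1 to compound 4 (0.24 log units; within the scatter) so these two aryl groups cannot be told apart here. Nothing measured explains the rise from methyl to sulfamoyl. On these data alone, whether an amine, a carboxylic acid or a longer chain at this position would move the number further stays open, as does whether sulfamoyl behaves the same alongside (3,5-dimethylphenyl)sulfonyl on the aromatic nitrogen.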